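The source may report more compounds than this note shows. Statements on the series, on what has been measured and on what is new or still open speak of the compounds shown alone.

In an ADME assay on HepG2 2.2.15 cells (Homo sapiens) for cytotoxicity, read by MTT assay, with stated times of 48 h and 9 days (a lower number here means that less compound is tolerated, a higher number that more compound is tolerated), the three measured compounds give:
compound 1 `COc1ccc2c(=O)c(/C=C/C(=O)Nc3ccc(C)cc3)coc2c1`: 979000 nM
compound 2 `COc1ccc2c(=O)c(/C=C/C(=O)Nc3ccc(Cl)cc3)coc2c1`: 272000 nM
compound 3 `COc1ccc2c(=O)c(/C=C/C(=O)NCc3ccc(C)cc3)coc2c1`: 257000 nM

Within the data shown here, compound 3 sits at the low end of these three numbers, but the step of a 1.1-fold lower number from compound 2 to compound 3 (0.02 log units; within the scatter) is within the scatter, and only the step of a 3.8-fold lower number from compound 1 to compound 3 (0.58 log units; beyond the scatter) is beyond it. Compound 4 `COc1ccc2c(=O)c(/C=C/C(=O)Nc3ccc(F)cc3)coc2c1` differs from compound 3 by 4-fluorophenyl in place of 4-methylbenzyl on an amide-type nitrogen. Two earlier steps bear on this. Exchanging 4-methylphenyl for 4-methylbenzyl lowered the number a 3.8-fold lower number from compound 1 to compound 3 (0.58 log units; beyond the scatter), so returning to a phenyl should raise it; exchanging methyl for chloro on the phenyl lowered it a 3.6-fold lower number from compound 1 to compound 2 (0.56 log units; beyond the scatter), and fluoro is another halogen. A modest rise in this assay is therefore expected, a 1.6-fold higher number from compound 3 to compound 4 (0.21 log units; within the scatter), giving compound 4 an estimated 420000 nM, between 180000 nM and 1000000 nM.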

Compound 4, half-maximal cytotoxic concentration: 743000 nM
Beside the measured number, compound 4's estimate is 1.8-fold (0.25 log units) below it; the range from low to high includes it.
By their numbers in this assay, from the lowest: compounds 3 and 2 (each within the scatter of the next); then compounds 4 and 1 (each within the scatter of the next).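

In this assay the two halogens on the phenyl do not behave alike: fluoro in place of chloro gives a 2.7-fold higher number from compound 2 to compound 4 (0.44 log units; beyond the scatter) while fluoro in place of methyl gives a 1.3-fold lower number from compound 1 to compound 4 (0.12 log units; within the scatter) and so leaves the number within the scatter. On the amide-type nitrogen, 4-fluorophenyl in place of 4-methylbenzyl gives a 2.9-fold higher number from compound 3 to compound 4 (0.46 log units; beyond the scatter) and shows that a benzyl group is not needed for this gap, since compound 2 also differs from compound 4 with a phenyl kept. No measured evidence here accounts for these steps.

Still open, as far as these compounds go, is where a 4-bromophenyl or a 4-methoxyphenyl on the amide-type nitrogen would fall. Also open, from the compounds shown here alone, is whether a 4-fluorobenzyl or a longer chain there would follow compound 3.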